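The compounds below may be only part of what the source reports. "The series", "measured", "known", "first", "only" and "open" are said of these compounds alone.

Compound 1 `Cc1ccc(-[n+]2noc([O-])c2CN2CCN(C)CC2)cc1` was tested in an ADME assay on HEL cells (Homo sapiens) for cytotoxicity (on this read-out lower numbers stand for higher toxicity in this test and higher numbers for lower toxicity in this test), where compound 1 gives 100 ug/mL. Compound 2 `Cc1ccc(-[n+]2noc([O-])c2CN2CCN(C)C(c3ccccc3)C2)cc1` differs from it by a phenyl in place of hydrogen on a saturated ring carbon, and in this assay compound 2 gives 100 ug/mL; the step of no change at the digits printed from compound 1 to compound 2 (within the scatter) is flat. Within the data shown here, compound 1 thus stands level with compound 2, its only measured neighbour. The compound now in question is compound 3 `Cc1ccc(-[n+]2noc([O-])c2CN2CCN(c3ccccc3)CC2)cc1`, which differs from compound 1 by phenyl in place of methyl on an amine nitrogen in a ring. Among the measured compounds shown here, only one measured step bears on this, no change at the digits printed from compound 1 to compound 2 (within the scatter), in which a phenyl entering elsewhere on the same saturated ring left the number unchanged. A phenyl on the ring nitrogen is a different change, but with nothing in the measured data pointing another way, no step beyond the scatter is expected, no change at the digits printed from compound 1 to compound 3 (within the scatter). Compound 3 is therefore estimated at 100 ug/mL, within a range from 50 ug/mL to 200 ug/mL.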

Compound 3, minimum cytotoxic concentration: 100 ug/mL
Estimate against measurement, compound 3: no gap at the digits printed; low and high end bracket the measured number.
By their numbers in this assay, from the lowest: compounds 1, 2 and 3 (each within the scatter of the next).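

In this assay, replacing the methyl on the ring nitrogen with a phenyl gives no change at the digits printed from compound 1 to compound 3 (within the scatter). The earlier step, no change at the digits printed from compound 1 to compound 2 (within the scatter), concerned a phenyl on a saturated ring carbon, so this result adds a second site on the same six-membered ring, the amine nitrogen, where a much larger group with an aromatic ring of its own leaves the read-out where it was. Nothing measured here explains why the number holds steady at this position.

As far as these compounds go, it remains open whether other groups on this nitrogen, such as a benzyl, an acetyl or a longer alkyl chain, would also leave the number in place. The same question stands for a chlorine atom or a carboxylic acid carried on the new phenyl.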